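Nitro to amino: an expected cytotoxicity outcome

The source may report more compounds than this note shows. Statements on the series, on what has been measured and on what is new or still open speak of the compounds shown alone.

Three compounds share one core and differ only in the group on the distal aromatic ring. Compound 1 `O=c1ccn(CCCCCOc2ccc(-c3ccccc3)cc2)c(=O)[nH]1` carries a phenyl there, compound 2 `O=c1ccn(CCCCCOc2ccc(Br)cc2)c(=O)[nH]1` a bromine, and compound 3 `O=c1ccn(CCCCCOc2ccc([N+](=O)[O-])cc2)c(=O)[nH]1` a nitro. In an ADME assay on HEL cells (Homo sapiens) for cytotoxicity (a higher number here means that more compound is tolerated, a lower number that less compound is tolerated), compound 1 gives "not determined" (no result reported). In this assay compound 2 reaches only a limit of the assay, > 100000 nM, and that is the single numerical entry in the set (the limit of > 100000 nM in this assay, at which 1 of the 3 values shown sits). In this assay compound 3 gives "not determined" (no result reported), so compound 3 stands without a number of its own, and one further neighbour is likewise without a result.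

Compound 4 `Nc1ccc(OCCCCCn2ccc(=O)[nH]c2=O)cc1` is the next compound, obtained by amino in place of nitro on an aromatic carbon. Going by the values given here, no measured step exists for this change, and nothing in the set points to a shift beyond the scatter in this assay in either direction. Compound 4 is therefore expected to give 100000 nM, within 30000 nM to 300000 nM, most likely again as a limit.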

Compound 4, half-maximal cytotoxic concentration: > 100000 nM
Compound 4: a limit, no number; the forecaster's own chance of this, stated with the estimate: 75%; the middle value lies on the limit itself.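

Going by these compounds alone, compound 2 and compound 4 both stop at a limit, so no step between them can be read in this assay: the limit of > 100000 nM in this assay, at which 2 of the 4 values shown sit.

The compounds shown leave open how much of compound 2 or compound 4 would be tolerated beyond that limit, and where compound 1 and compound 3 stand in this assay.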